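The source may hold more compounds than are shown below. What is called first, only, known or untested is meant among the compounds shown, and "the series" means these compounds.

Compound 1, `Cc1cccc(CNc2ncnc3c2ncn3[C@@H]2O[C@H](CO)[C@@H](O)[C@H]2O)c1`, shows 19100 nM
Compound 2, `COc1cc(CNc2ncnc3c2ncn3[C@@H]2O[C@H](CO)[C@@H](O)[C@H]2O)cc(OC)c1O`, shows "not determined" (no result reported)
Compound 3, `Cc1cccc(CNc2ncnc3c2ncn3[C@@H]2O[C@H](CO)[C@@H](O)[C@H]2O)c1O`: not yet measured

Going by the values given here, in a functional assay on CCRF-CEM cells (Homo sapiens) for antiproliferative activity, with a stated time of 72 h (on this read-out lower numbers stand for stronger inhibition and higher numbers for weaker inhibition), compound 1 gives 19100 nM, and this is the only number available; compound 2 carries "not determined" (no result reported), so compound 1 cannot be placed against any other compound, and no measured step exists to lean on. Compound 3 is obtained from compound 1 by a single change: hydroxy in place of hydrogen on an aromatic carbon. The hydroxy group enters on the six-membered aromatic ring of carbon only, ortho to the methyl group and ortho to the large group that joins the ring to the shared core. With no comparison at hand, there is no basis for a direction, and the step from compound 1 to compound 3 is expected to stay small, a 1.2-fold lower number from compound 1 to compound 3 (0.08 log units; within the scatter), possibly within the usual scatter. Compound 3 is therefore estimated at 16000 nM, with a likely range from 5000 nM to 50000 nM.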

Compound 3, half-maximal inhibitory concentration: 900 nM
Compound 3: the middle estimate sits 18-fold (1.25 log units) above what was measured; the whole stated range lies above it.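

In this assay, one hydroxy group on the aromatic carbon ortho to the methyl group and ortho to the large group gives a 21-fold lower number from compound 1 to compound 3 (1.33 log units; beyond the scatter) and so counts as a large step. This shows that the position is not indifferent: going from 3-methylbenzyl to 2-hydroxy-3-methylbenzyl adds only one heavy atom, yet it changes the read-out strongly, which the lone number for compound 1 could not reveal. Nothing shown here speaks to why the hydroxy group has this effect.

Going by these compounds, it remains open whether a methoxy group or an amine at the same place would give a similar step, or whether only hydroxy does. On these data alone, it is also open whether the step depends on the methyl group, which a 2-hydroxybenzyl group would test.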